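A Phenyl Swap on the Ring Nitrogen of Compound 3

A few compounds are considered here, and "the series" means these few. Any claim that something is new, unique, unknown or untested is made for them only; others in the source may bear on it.

Of the compounds shown here, three share a core and have been measured in a functional assay on A549 cells (Homo sapiens) for cytotoxicity, read by MTT assay, with a stated time of 72 h; on this read-out lower numbers stand for stronger inhibition and higher numbers for weaker inhibition. Compound 1, `Cc1cc(=O)n(-c2ccccc2C(F)(F)F)nc1C(=O)Nc1ccc(Oc2ncnc3ccsc23)c(F)c1`, gives 4680 nM. Compound 2, `Cc1cc(=O)n(-c2ccc(Br)cc2F)nc1C(=O)Nc1ccc(Oc2ncnc3sccc23)cc1`, gives 12800 nM. Compound 3, `O=C(Nc1ccc(Oc2ncnc3ccsc23)c(F)c1)c1nn(-c2ccc(F)c(Cl)c2)ccc1=O`, gives 9650 nM, which places it second highest of the three numbers: its number lies within the scatter of that of compound 2, while that of compound 1 lies beyond the scatter below it.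

Compound 4, `O=C(Nc1ccc(Oc2ncnc3ccsc23)c(F)c1)c1nn(-c2ccccc2)ccc1=O`, is the compound awaiting measurement. It differs from compound 3 in one place: phenyl in place of 3-chloro-4-fluorophenyl on an aromatic nitrogen. Among the compounds with values here, no pair of measured compounds differs in this single place, so no step of this kind has been seen directly in this assay. The loss of both halogens from the aryl group on the nitrogen is expected to leave the number near that of compound 3 or to raise it modestly, with the step from compound 3 to compound 4 estimated at a 1.2-fold higher number from compound 3 to compound 4 (0.09 log units; within the scatter). Compound 4 is therefore expected to give about 12000 nM, with a range from 4000 nM to 36000 nM in this assay.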

Compound 4, half-maximal inhibitory concentration: 19700 nM
For compound 4 the middle estimate is 1.6-fold (0.22 log units) below the measured one; the range from low to high includes it.
By their numbers in this assay, from the lowest: compound 1; then compounds 3, 2 and 4 (each within the scatter of the next, the first and the last beyond it).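

In this assay, within the data shown here, this is the first direct reading of a change to the aryl group on this aromatic nitrogen: a 2.0-fold higher number from compound 3 to compound 4 (0.31 log units; beyond the scatter). Although modest, the step shows that phenyl and 3-chloro-4-fluorophenyl are not interchangeable at this position, with the halogen-bearing group giving the lower number of the pair. Nothing in the available data accounts for this difference.

The compounds shown leave open whether the chlorine, the fluorine or the two together carry the step, which a phenyl bearing only one of these halogens would help to separate. They also leave open how this nitrogen would tolerate a group other than a directly attached aryl ring, such as a benzyl group or a longer alkyl chain.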